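A few compounds are considered here, and "the series" means these few. Any claim that something is new, unique, unknown or untested is made for them only; others in the source may bear on it.

Measured compounds: compound 1, `Cc1ccc(-n2nncc2CN2C(=O)C3(C(C#N)=C(N)Oc4c3c3nc5ccccc5nc3c3ccccc43)c3ccccc32)cc1C`, > 50000 nM; compound 2, `CCc1ccccc1-n1nncc1CN1C(=O)C2(C(C#N)=C(N)Oc3c(N)cc4nc5ccccc5nc4c32)c2ccccc21`, 24600 nM.

In a functional assay on MCF7 cells (Homo sapiens) for antiproliferative activity, read by MTT assay, with a stated time of 48 h (on this read-out lower numbers stand for stronger inhibition and higher numbers for weaker inhibition), compound 1 reaches only (the limit of > 50000 nM in this assay, at which 1 of the 2 values shown sits), a limit of the assay rather than a number. In this assay, among the compounds with values here, compound 2 gives 24600 nM, the only number among the two values shown. Within the data shown here, compound 1 and compound 2 differ in more than one place, so their two values show no single step.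

Compound 3, `Cc1cc(C)cc(-n2nncc2CN2C(=O)C3(C(C#N)=C(N)Oc4c(N)cc5nc6ccccc6nc5c43)c3ccccc32)c1`, has not yet been measured. It differs from compound 2 by 3,5-dimethylphenyl in place of 2-ethylphenyl on an aromatic nitrogen, the same atoms joined differently, with no change in hydrogen-bond donors or acceptors. Among the measured compounds shown here, no measured pair isolates this change, so the step from compound 2 to compound 3 in this assay is expected to be small, in no clear direction, and not beyond the scatter. Compound 3 is therefore expected to give about 30000 nM, estimated between 10000 nM and 60000 nM, an expected step of a 1.2-fold higher number from compound 2 to compound 3 (0.09 log units; within the scatter).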

Compound 3, half-maximal inhibitory concentration: > 50000 nM
Compound 3 gave a limit, no number (the forecaster's own chance of this, stated with the estimate: 35%); middle value at least 1.6-fold (0.22 log units) away from the limit.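

Within the data shown here, this is the first readable step at this position: in this assay, 3,5-dimethylphenyl in place of 2-ethylphenyl on an aromatic nitrogen gives an at least 2.0-fold higher number from compound 2 to compound 3 (0.30 log units; that floor lies within the scatter). The swap keeps the same atoms joined differently and brings no lower number, although the floor of the step does not pass beyond the scatter. For compound 3, > 50000 nM is a limit of the assay and not a number: the limit of > 50000 nM in this assay, at which 2 of the 3 values shown sit.

The size of the step past its floor stays open, as does the cause of the difference between these two substituents. The compounds shown also leave open how this phenyl would read with a single methyl, a methoxy or an amine on it, or with a benzyl group in its place.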